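A swap of one aromatic group on the shared core

The source may hold more compounds than are shown below. What is called first, only, known or untested is meant among the compounds shown, and "the series" means these compounds.

In a functional assay on MCF7 cells (Homo sapiens) for antiproliferative activity, read by MTT assay, with a stated time of 48 h (on this read-out higher numbers stand for weaker inhibition and lower numbers for stronger inhibition), compound 1 `COc1ccc(-c2c(Nc3cc(OC)c(OC)c(OC)c3)c3ccccc3oc2=O)cc1` gives 82300 nM and compound 2 `COc1ccc(-c2c(Nc3ccc(C)cc3)c3ccccc3oc2=O)cc1` gives 65300 nM and these two values lie within the usual scatter of each other. The change 3-(trifluoromethyl)phenyl in place of 4-methylphenyl on a nitrogen on an aromatic ring turns compound 2 into compound 3 `COc1ccc(-c2c(Nc3cccc(C(F)(F)F)c3)c3ccccc3oc2=O)cc1` by putting 3-(trifluoromethyl)phenyl in place of 4-methylphenyl on a nitrogen on an aromatic ring. Within the data shown here, no measured step yet shows what this swap does in this assay so no shift beyond the scatter is expected. The estimated 1.1-fold lower number from compound 2 to compound 3 (0.04 log units; within the scatter) is expected to stay within that scatter. Compound 3 is expected at 60000 nM within an estimated range of 25000 nM to 120000 nM for now.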

Compound 3, half-maximal inhibitory concentration: 21600 nM
Beside the measured number, compound 3's estimate is 2.8-fold (0.44 log units) above it; the measured number lies below the stated range.
By their numbers in this assay, from the lowest: compound 3; then compounds 2 and 1 (each within the scatter of the next).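

In this assay the change to 3-(trifluoromethyl)phenyl from 4-methylphenyl on a nitrogen on an aromatic ring gives a 3.0-fold lower number from compound 2 to compound 3 (0.48 log units; beyond the scatter) and so shows that the group at this position can move the number beyond the scatter. Compound 1 and compound 2 lie within the scatter of each other and could not show this. Nothing available here explains the shift.

The compounds shown leave open whether trifluoromethyl itself matters here. They also leave open what an amine or a carboxylic acid on this phenyl ring would do.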